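Compound 3: naphthalen-2-yl replacing 4-bromo-2-chlorophenyl

The source may hold more compounds than are shown below. What is called first, only, known or untested is meant among the compounds shown, and "the series" means these compounds.

In an ADME assay on HepG2 cells (Homo sapiens) for cytotoxicity, read by MTT assay, with a stated time of 24 h (a lower number here means a stronger inhibitor, a higher number a weaker inhibitor), compound 1 (`CCOS(=O)(=O)/C=C/c1ccc(OCC2=CC[C@@H]3C(C(=O)Nc4ccc(Oc5ccccc5)cc4)=CO[C@@H](OC)[C@H]23)cc1`) gives > 200000 nM as a limit of the assay and not a number. Compound 2 (`CCOS(=O)(=O)/C=C/c1ccc(OCC2=CC[C@@H]3C(C(=O)Nc4ccc(Oc5ccc(Br)cc5Cl)cc4)=CO[C@@H](OC)[C@H]23)cc1`) gives > 200000 nM in this assay as a limit of the assay and not a number. Compound 2 therefore has no numerical reading and stands with compound 1 at the limit of > 200000 nM in this assay, at which 2 of the 2 values shown sit, in these notes.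

Compound 3 (`CCOS(=O)(=O)/C=C/c1ccc(OCC2=CC[C@@H]3C(C(=O)Nc4ccc(Oc5ccc6ccccc6c5)cc4)=CO[C@@H](OC)[C@H]23)cc1`) differs from compound 2 by naphthalen-2-yl in place of 4-bromo-2-chlorophenyl on an oxygen on an aromatic ring and otherwise keeps the same structure. Going by the values given here, the only measured step bearing on this change is a step that the two limits leave unreadable from compound 1 to compound 2 at the same place, so it sets no size. No step beyond the scatter is expected in this assay in either direction. The expected change is a number no higher from compound 2 to compound 3 (the limit leaves the size open) as an estimate only. For compound 3 the estimated value is 200000 nM with an expected range of 80000 nM to 400000 nM in this assay.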

Compound 3, half-maximal inhibitory concentration: > 200000 nM
Compound 3 was reported as a limit (the forecaster's own chance of this, stated with the estimate: 85%); the middle value lies on the limit itself.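

No step can be read among compound 1, compound 2 and compound 3 in this assay, since each reading is a limit of the assay and not a number: the limit of > 200000 nM in this assay, at which 3 of the 3 values shown sit. Going by these compounds, whether phenyl, 4-bromo-2-chlorophenyl and naphthalen-2-yl on this oxygen differ at all in this assay stays open.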